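A few compounds are considered here, and "the series" means these few. Any claim that something is new, unique, unknown or untested is made for them only; others in the source may bear on it.

In a functional assay on HUVEC cells (Homo sapiens) (on this read-out higher numbers stand for an effect only at larger amounts of compound and lower numbers for an effect already at smaller amounts), compound 1 `COC1=C(C)C(=O)/C(=C(O)/C=C/c2ccc(C)cc2)C(=O)C1(C)C` gives < 4 ug/mL, which is a limit and not a number. Compound 2 `CCc1ccc(/C=C/C(O)=C2/C(=O)C(C)=C(OC)C(C)(C)C2=O)cc1` gives < 4 ug/mL, which is also a limit and not a number. Compound 2 therefore has no exact position, and the picture so far is the limit of < 4 ug/mL in this assay, at which 2 of the 2 values shown sit. Going by the values given here, the one measured step is a step that the two limits leave unreadable from compound 1 to compound 2, so it offers no size to carry forward. The next structure, compound 3 `COC1=C(C)C(=O)/C(=C(O)/C=C/c2c(C)cccc2C)C(=O)C1(C)C`, keeps the shared core, and the change is 2,6-dimethylphenyl in place of 4-ethylphenyl on a double-bonded chain carbon bound to a double-bonded chain carbon. The two have the same atoms, joined differently. Among the compounds with values here, no measured step covers a change of this kind, so no direction can be argued in this assay, and nothing beyond the usual scatter is expected. The estimated change is a step that the limit leaves unreadable from compound 2 to compound 3. For compound 3, the estimated value is 2.5 ug/mL, with an expected range from 0.8 ug/mL to 8 ug/mL.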

Compound 3, concentration for half-maximal effect: < 4 ug/mL
Compound 3 was reported as a limit; the forecaster's own chance of this, stated with the estimate: 65%; the middle value is on the limit's open side.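

The steps among compound 1, compound 2 and compound 3 cannot be read, as all three results are limits and not numbers in this assay: the limit of < 4 ug/mL in this assay, at which 3 of the 3 values shown sit.

Going by these compounds, the exact value of each compound remains open, and so does whether the 4-methylphenyl, 4-ethylphenyl and 2,6-dimethylphenyl groups make any difference.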